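The source may hold more compounds than are shown below. What is called first, only, known or untested is meant among the compounds shown, and "the series" means these compounds.

Compound 1 `CC(C)(C)OC(=O)CN(Cc1ccc(Cl)cc1)Cc1ccc([N+](=O)[O-])s1` — 500 nM
Compound 2 `COc1cccc(CN(Cc2cccnc2)Cc2ccc([N+](=O)[O-])s2)c1` — 400 nM
Compound 3 `Clc1ccc(CN(Cc2cccnc2)Cc2ncc[nH]2)cc1` — a limit of the assay, not a number

In an assay on isolated protein for agonist activity at nuclear receptor subfamily 1 group D member 1 (Homo sapiens), read by FRET, with a stated time of 1 h (on this read-out higher numbers stand for an effect only at larger amounts of compound and lower numbers for an effect already at smaller amounts), compound 1 gives 500 nM, the higher of the two numbers shown. Compound 2 gives 400 nM in this assay, and the gap between the two lies within the usual scatter, so the two read as alike. For compound 3 the result is only a limit of the assay, > 50000 nM, not a number. Compound 3 thus sits at the limit of > 50000 nM in this assay, at which 1 of the 3 values shown sits.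

Compound 4 `O=[N+]([O-])c1ccc(CN(Cc2ccc(Cl)cc2)Cc2ccccc2F)s1` has not been measured yet. It differs from compound 1 in one place: 2-fluorophenyl in place of tert-butoxycarbonyl on a saturated chain carbon bound to an amine nitrogen. Among the measured compounds shown here, no pair of measured compounds shows what such a swap does here, so the expectation rests on compound 1 alone, with compound 2 showing that the shared part tolerates a change at the other arm without leaving the scatter. A step from compound 1 to compound 4 of about a 1.7-fold lower number from compound 1 to compound 4 (0.22 log units; within the scatter) is expected, no larger than a modest gain. Compound 4 is therefore estimated at 300 nM, with a range from 80 nM to 1500 nM.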

Compound 4, half-maximal effective concentration: 63 nM
The estimate for compound 4 lay 4.8-fold (0.68 log units) above the measured number; measured number below the stated range.
By their numbers in this assay, from the lowest: compound 4; then compounds 2 and 1 (each within the scatter of the next). At a limit, above all of these: compound 3.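

In this assay, exchanging tert-butoxycarbonyl for 2-fluorophenyl on a saturated chain carbon bound to an amine nitrogen gives a 7.9-fold lower number from compound 1 to compound 4 (0.90 log units; beyond the scatter), so this position responds clearly to the group it carries. The tert-butoxycarbonyl group is therefore not needed for an effect in this series, as an aromatic ring of carbon bearing fluorine serves at least as well in its place. The data shown offer no measured property that explains a step of this size.

This single swap changes the ring and the fluorine together, so a plain benzyl group would be needed to show what the fluorine itself contributes. Going by these compounds, it also remains open how this position would respond to a carboxylic acid, an amine or a longer chain.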